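The source may hold more compounds than are shown below. What is called first, only, known or untested is meant among the compounds shown, and "the series" means these compounds.

Measured so far in an assay for inhibition of Polyunsaturated fatty acid lipoxygenase ALOX15 (Oryctolagus cuniculus); a higher number here means a weaker inhibitor, a lower number a stronger inhibitor:
Compound 1 `N#Cc1ccn2c(-c3ccccc3)c(-c3ccccc3)c(Cc3ccccc3)c2c1` gives 46000 nM.
Compound 2 `N#Cc1ccn2c(-c3ccccc3)c(-c3ccccc3)c(OCOCc3ccccc3)c2c1` gives 39000 nM.
Compound 3 `N#Cc1ccn2c(-c3ccccc3)c(-c3ccccc3)c(C(=O)c3ccccc3)c2c1` gives 43000 nM.

The three compounds share one core and differ only in the group carried on one aromatic carbon of the five-membered ring. Compound 3 stands second highest of the three numbers in this assay, but the steps of a 1.1-fold lower number from compound 1 to compound 3 (0.03 log units; within the scatter) and a 1.1-fold higher number from compound 2 to compound 3 (0.04 log units; within the scatter) both lie within the scatter, so no order among the three can be read from them.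

Compound 4 `N#Cc1ccn2c(-c3ccccc3)c(-c3ccccc3)c(C(O)c3ccccc3)c2c1` differs from compound 3 in one place: hydroxy(phenyl)methyl in place of benzoyl on an aromatic carbon. Every step measured so far swaps the group at this same place for another: a 1.2-fold lower number from compound 1 to compound 2 (0.07 log units; within the scatter), a 1.1-fold lower number from compound 1 to compound 3 (0.03 log units; within the scatter) and a 1.1-fold higher number from compound 2 to compound 3 (0.04 log units; within the scatter). All three are within the scatter, whether the group carries a carbonyl, a chain of oxygens or only carbon. None of them exchanges benzoyl for hydroxy(phenyl)methyl directly, so the expectation rests on this pattern alone, and the expected step is a 1.0-fold lower number from compound 3 to compound 4 (0.01 log units; within the scatter), none beyond the scatter. Compound 4 is therefore estimated to give 42000 nM, with a range from 22000 nM to 80000 nM.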

Compound 4, half-maximal inhibitory concentration: 48000 nM
Beside the measured number, compound 4's estimate is 1.1-fold (0.06 log units) below it; measured number inside the range.
By their numbers in this assay, from the lowest: compounds 2, 3, 1 and 4 (each within the scatter of the next).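

In this assay, going by these compounds alone, hydroxy(phenyl)methyl is the only group of the four with a hydrogen-bond donor, yet exchanging benzoyl for it gives a 1.1-fold higher number from compound 3 to compound 4 (0.05 log units; within the scatter) and no step beyond the scatter. Exchanging (benzyloxy)methoxy for it gives a 1.2-fold higher number from compound 2 to compound 4 (0.09 log units; within the scatter) and adding hydroxy in place of hydrogen on the saturated chain carbon of benzyl gives a 1.0-fold higher number from compound 1 to compound 4 (0.02 log units; within the scatter) as well. So at this place, the presence of a hydrogen-bond donor on the group separates none of the four compounds, just as the carbonyl and the chain of oxygens separated none before it.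

Nothing available bears on why this is so. On these data alone, whether a group of another kind on this carbon, such as an amine or a carboxylic acid, would give a step beyond the scatter stays open.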